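A few compounds are considered here, and "the series" means these few. Any claim that something is new, unique, unknown or untested is made for them only; others in the source may bear on it.

Compound 1 `CO/N=C1\C[C@@H](c2ccc(Cl)cc2)N[C@@H](c2ccc(Cl)cc2)[C@@H]1C` and compound 2 `CO/N=C1\C[C@@H](c2ccc(OC)cc2)N[C@@H](c2ccc(OC)cc2)[C@@H]1C` share a six-membered non-aromatic ring with one nitrogen; how their two cores differ is not broken down here. In a functional assay on HeLa cells (Homo sapiens) for inhibition, read by MTT assay, with a stated time of 24 h (a lower number here means a stronger inhibitor, a higher number a weaker inhibitor), compound 1 gives 49000 nM, while compound 2 gives 154000 nM, the highest number among the measured compounds. Compound 3 `CO/N=C1\C[C@@H](c2ccc(Cl)cc2)N(C)[C@@H](c2ccc(Cl)cc2)[C@@H]1C` arises from compound 1 by a single change, (methyl in place of hydrogen on an amine nitrogen in a ring). In this assay compound 3 gives 36300 nM, which makes the step of a 1.3-fold lower number from compound 1 to compound 3 (0.13 log units; within the scatter). Compound 4 `CO/N=C1\C[C@@H](c2ccc(OC)cc2)N(C)[C@@H](c2ccc(OC)cc2)[C@@H]1C` arises from compound 2 by the same kind of change, (methyl in place of hydrogen on an amine nitrogen in a ring); the surroundings are not identical, since the ring atoms next to the amine nitrogen bear 4-methoxyphenyl groups here but 4-chlorophenyl groups in compound 3. Because the earlier step of a 1.3-fold lower number from compound 1 to compound 3 (0.13 log units; within the scatter) stayed within the scatter, a similarly small step is expected here, a 1.3-fold lower number from compound 2 to compound 4 (0.11 log units; within the scatter). Compound 4 is therefore estimated to give 120000 nM, with most repeat measurements expected to fall between 60000 nM and 250000 nM.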

Compound 4, half-maximal inhibitory concentration: 80600 nM
Estimate against measurement, compound 4: 1.5-fold (0.17 log units) above, and the stated range covers the measured number.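

In this assay the methyl in place of hydrogen on the amine nitrogen, now on the core bearing 4-methoxyphenyl groups, gives a 1.9-fold lower number from compound 2 to compound 4 (0.28 log units; within the scatter) and so stays inside the normal spread of repeat measurements. Set beside the same change on the core bearing 4-chlorophenyl groups, the two steps cannot be told apart: the same change on two cores in this assay, a 1.3-fold lower number (0.13 log units; within the scatter) from compound 1 to compound 3 and a 1.9-fold lower number (0.28 log units; within the scatter) from compound 2 to compound 4, 1.4-fold (0.15 log units) apart, within the scatter of two such steps. On these two cores, then, the change carries over in the sense that neither step is large enough to count as a real shift, but two small steps cannot show that the methyl is without effect, nor that the same would hold on a different core.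

On these data alone, what a longer chain such as ethyl, or an acetyl group, would do on that nitrogen remains open. So does whether the step would stay this small with a hydroxyl group or fluorine on the phenyl rings in place of the chlorine or methoxy groups.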